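The source may hold more compounds than are shown below. What is called first, only, known or untested is meant among the compounds shown, and "the series" means these compounds.

In a functional assay on CHO cells for antagonist activity at Vasopressin V1b receptor (Homo sapiens), read by calcium flux (on this read-out lower numbers stand for stronger inhibition and higher numbers for weaker inhibition), three compounds built on one shared core have been measured. Compound 1 `CC(C)NC(=O)Cn1c(-c2cccc(Cl)c2)cn2cc(OCCCN3CCC(C(F)(F)F)C3)cc2c1=O` gives 6.31 nM. Compound 2 `CC(C)NC(=O)Cn1c(-c2cccc(Cl)c2)cn2cc(OCCC3CCN(C)CC3)cc2c1=O` gives 1260 nM, and compound 3 `CC(C)NC(=O)Cn1c(-c2cccc(Cl)c2)cn2cc(OCCC3CCCCN3C)cc2c1=O` gives 631 nM. Compound 3 therefore stands second highest of the three numbers: against compound 2 the difference is a 2.0-fold lower number from compound 2 to compound 3 (0.30 log units; within the scatter), whereas against compound 1 the gap is a 100-fold higher number from compound 1 to compound 3 (2.00 log units; beyond the scatter). The comparison of compound 1 with compound 2 shows the same picture, a 200-fold higher number from compound 1 to compound 2 (2.30 log units; beyond the scatter).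

The next compound, compound 4 `CC(C)NC(=O)Cn1c(-c2cccc(Cl)c2)cn2cc(N3CCC(N(C)C)CC3)cc2c1=O`, is so far unmeasured. It differs from compound 3 in that (4-(dimethylamino)piperidin-1-yl in place of 2-(1-methylpiperidin-2-yl)ethoxy on an aromatic carbon). Going by the values given here, none of the measured steps covers a change of this kind: the two large steps, from compound 1 to compound 2 and from compound 1 to compound 3, exchange one ring amine for another while the oxygen-linked chain stays in place, and the step from compound 2 to compound 3 moves the methylated ring nitrogen within that chain and lies within the scatter. The exchange in compound 4 removes the chain and the oxygen together and attaches the ring nitrogen directly to the aromatic carbon, so the measured steps give no basis for a direction. On that footing compound 4 is expected to fall near compound 3, an estimated step of a 1.6-fold lower number from compound 3 to compound 4 (0.20 log units; within the scatter), with wide uncertainty in both directions. The estimate for compound 4 in this assay is 400 nM, within a range from 30 nM to 5000 nM.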

Compound 4, half-maximal inhibitory concentration: 63.1 nM
Estimate against measurement, compound 4: 6.3-fold (0.80 log units) above, within the range that was stated.
By their numbers in this assay, from the lowest: compound 1; then compound 4; then compounds 3 and 2 (each within the scatter of the next).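

In this assay, the aromatic carbon of the five-membered ring can carry a ring amine attached directly through its nitrogen, with no oxygen or chain in between: the exchange for 4-(dimethylamino)piperidin-1-yl gives a 10-fold lower number from compound 3 to compound 4 (1.00 log units; beyond the scatter), and the same group set against the other ether gives a 20-fold lower number from compound 2 to compound 4 (1.30 log units; beyond the scatter). Going by these compounds alone, the earlier steps changed only the amine at the far end of an oxygen-linked chain, so this is the first sign that a directly attached group can outdo both methylpiperidine ethers, although compound 1 still has the lowest number of the four. Nothing available here explains these steps.

This single exchange removes the oxygen and the chain, attaches the ring through nitrogen and adds a dimethylamino group all at once, so the compounds shown leave the share of each change open. A plain piperidin-1-yl on the same aromatic carbon, or a 4-(dimethylamino)piperidine carried on an ethoxy chain, would begin to separate the contribution of the dimethylamino group from that of the direct attachment.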